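This account rests on a few compounds, and the source may have more. Where it says the series, first, only, none or still open, it means among the compounds named here.

In a functional assay on MCF7 cells (Homo sapiens) for antiproliferative activity, read by WST assay, with a stated time of 48 h (on this read-out lower numbers stand for stronger inhibition of growth and higher numbers for weaker inhibition of growth), compound 1 `CCCCC/C=C/c1c(O)ccc(O)c1CO` gives 61500 nM. Compound 2 `CCCCCC[C@H](O)c1c(O)ccc(O)c1CO` gives > 100000 nM, which is a limit of the assay and not a number. Among the measured compounds shown here, the series so far therefore includes (the limit of > 100000 nM in this assay, at which 1 of the 2 values shown sits), and the true position of compound 2 remains open. For the measured compounds named here, no two measured compounds differ in only one place, so no measured step is available to calibrate the next change.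

The next compound is compound 3 `CCCCCC[C@@H](O)c1c(O)ccc(O)c1CO`, and the change from compound 2 is one of configuration only (the two compounds have the same atoms and bonds and differ only in configuration as drawn: 1 of 1 stereo elements differ; a stereocentre at a saturated chain carbon is drawn S in compound 2 and R in compound 3). The same atoms and bonds remain, while a stereocentre at a saturated chain carbon is drawn S in compound 2 and R in compound 3.

In this assay, the expectation is for no step beyond the usual scatter, with neither direction favoured. With compound 2 reading > 100000 nM, a limit is also a likely result for compound 3. The expected step, a number no higher from compound 2 to compound 3 (the limit leaves the size open), is an estimate anchored only on that limit. Compound 3 is estimated at 100000 nM, with an expected range of 50000 nM to 200000 nM.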

Compound 3, concentration for 50% growth inhibition: > 100000 nM
Compound 3: a limit, no number; the forecaster's own chance of this, stated with the estimate: 60%; the middle value sits exactly at the limit.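

Compound 3 reads > 100000 nM in this assay, which is a limit of the assay and not a number. Compound 2 also sits at a limit, so no step can be read between compound 2 and compound 3. The compounds shown leave open where either compound truly lies and whether the two drawn configurations differ in growth inhibition at all.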